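Two Furan Rings on a Shared Core

A few compounds are considered here, and "the series" means these few. Any claim that something is new, unique, unknown or untested is made for them only; others in the source may bear on it.

Compound 1 `Nc1nc(-c2ccco2)nc2sc(-c3ccccc3)nc12` and compound 2 `Nc1nc(-c2cccc(O)c2)nc2sc(-c3ccco3)nc12` share one core. In a functional assay on CHO cells for antagonist activity at adenosine receptor A2b (Homo sapiens), read by cAMP accumulation, with a stated time of 10 min (on this read-out lower numbers stand for stronger inhibition and higher numbers for weaker inhibition), compound 1 gives only a limit of the assay, > 30000 nM. In this assay compound 2 likewise gives only a limit, > 30000 nM. Compound 2 thus stands at the limit of > 30000 nM in this assay, at which 2 of the 2 values shown sit, with no numerical value on record. Compound 3 `Nc1nc(-c2ccco2)nc2sc(-c3ccco3)nc12` differs from compound 2 by furan-2-yl in place of 3-hydroxyphenyl on an aromatic carbon. Within the data shown here, with both values shown sitting at a limit, no measured step can guide the expectation. The step of a number no higher from compound 2 to compound 3 (the limit leaves the size open) is expected to be none beyond the scatter. Compound 3 is expected to give about 30000 nM in this assay, within 5000 nM to 100000 nM, most likely again only as a limit.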

Compound 3, half-maximal inhibitory concentration: > 30000 nM
Compound 3: no number, only a limit; the forecaster's own chance of this, stated with the estimate: 75%; the middle value sits exactly at the limit.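

No new step can be read between compound 3 and either compound 1 or compound 2, because all three sit at one limit: the limit of > 30000 nM in this assay, at which 3 of the 3 values shown sit.

The compounds shown leave open whether furan-2-yl, phenyl or 3-hydroxyphenyl on the shared core makes any difference in this assay.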